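Methyl for Bromo in a Series Stuck at the Limit

The source may report more compounds than this note shows. Statements on the series, on what has been measured and on what is new or still open speak of the compounds shown alone.

Compound 3 `Fc1cccc(-c2nc(Nc3ccc(Br)cc3)c3cc(F)ccc3n2)c1` is one of three related compounds tested in a functional assay on U-937 cells (Homo sapiens) for cytotoxicity, read by MTT assay, with a stated time of 48 h; a higher number here means a weaker inhibitor, a lower number a stronger inhibitor. For compound 3 the result is only a limit, > 50000 nM. Compound 1 `Fc1cccc(-c2nc(Nc3ccccc3)c3ccccc3n2)c1` also gives only a limit in this assay, > 50000 nM. Compound 2 `Fc1ccc2nc(-c3ccccc3)nc(Nc3ccccc3)c2c1` likewise reaches only a limit, > 50000 nM. All three results rest on (the limit of > 50000 nM in this assay, at which 3 of the 3 values shown sit), so compound 3 can be placed neither above nor below its neighbours. Compound 4 `Cc1ccc(Nc2nc(-c3cccc(F)c3)nc3ccc(F)cc23)cc1` differs from compound 3 by methyl in place of bromo on an aromatic carbon, turning (4-bromophenyl)amino into (4-methylphenyl)amino. For the measured compounds named here, no step between two measured compounds exists to size this change against. The step that the limit leaves unreadable from compound 3 to compound 4 is therefore expected to be none beyond the scatter. The estimate for compound 4 is 60000 nM, with a range from 20000 nM to 200000 nM.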

Compound 4, half-maximal inhibitory concentration: > 50000 nM
Compound 4: no number, only a limit (the forecaster's own chance of this, stated with the estimate: 80%); the middle value lies beyond the limit too.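

In this assay, for the compounds shown here, no step from compound 3 to compound 4 can be read, because both results are only limits: the limit of > 50000 nM in this assay, at which 4 of the 4 values shown sit. The compounds shown leave open how methyl and bromo compare on the shared core, and what number any of the four would give.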